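Chloro for methoxy on the anilino ring: an expected small step

The compounds below may be only part of what the source reports. "The series", "measured", "known", "first", "only" and "open" are said of these compounds alone.

Compound 1, `CCS(=O)(=O)Nc1cc(-c2ccc3ncnc(Nc4cccc(F)c4)c3c2)cnc1OC`, gives 3940 nM in a functional assay on HCT-116 cells (Homo sapiens) for cytotoxicity, read by sulforhodamine B assay, with a stated time of 72 h; a lower number here means a stronger inhibitor, a higher number a weaker inhibitor.
Compound 2, `CCS(=O)(=O)Nc1cc(-c2ccc3ncnc(Nc4ccc(OC)cc4)c3c2)cnc1OC`, gives 3490 nM in this assay.
Compound 3, `CCS(=O)(=O)Nc1cc(-c2ccc3ncnc(Nc4ccc(OC)c(OC)c4)c3c2)cnc1OC`, gives 4360 nM in this assay.

Compound 3 sits at one end of these three numbers, but the step of a 1.1-fold higher number from compound 1 to compound 3 (0.04 log units; within the scatter) and the step of a 1.2-fold higher number from compound 2 to compound 3 (0.10 log units; within the scatter) are both within the scatter, so no order among the three compounds can be claimed. Compound 4, `CCS(=O)(=O)Nc1cc(-c2ccc3ncnc(Nc4ccc(OC)c(Cl)c4)c3c2)cnc1OC`, differs from compound 3 by chloro in place of methoxy on an aromatic carbon. The closest measured steps are all changes on the same aromatic ring: a 1.2-fold higher number from compound 2 to compound 3 (0.10 log units; within the scatter), a 1.1-fold lower number from compound 1 to compound 2 (0.05 log units; within the scatter) and a 1.1-fold higher number from compound 1 to compound 3 (0.04 log units; within the scatter), every one of them within the scatter. On that basis the step to compound 4 is expected to be small as well, in neither direction beyond the scatter: the estimated step is a 1.1-fold lower number from compound 3 to compound 4 (0.06 log units; within the scatter). Compound 4 is therefore expected to give about 3800 nM in this assay, with a range from 1900 nM to 7600 nM.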

Compound 4, half-maximal inhibitory concentration: 5620 nM
For compound 4 the middle estimate is 1.5-fold (0.17 log units) below the measured one; the range from low to high includes it.
By their numbers in this assay, from the lowest: compounds 2, 1, 3 and 4 (each within the scatter of the next).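

Chloro in place of methoxy on this aromatic carbon, ortho to a methoxy group, gives a 1.3-fold higher number from compound 3 to compound 4 (0.11 log units; within the scatter) in this assay, so here a chlorine atom and a methoxy group cannot be told apart. Chloro in place of hydrogen on the same carbon reads the same way, with a 1.6-fold higher number from compound 2 to compound 4 (0.21 log units; within the scatter), and the whole 3-chloro-4-methoxyphenyl group in place of 3-fluorophenyl gives a 1.4-fold higher number from compound 1 to compound 4 (0.15 log units; within the scatter). All four compounds therefore stay within the scatter of one another in this assay, now with hydrogen, methoxy or chloro at this carbon.

On these data alone, whether an amine or a carboxylic acid on this carbon, or a longer chain in place of the methoxy, would move the number beyond the scatter stays open. No measurement at hand speaks to what lies behind these small steps.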